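Compound 3 to compound 4: bromo in place of methyl

The source may report more compounds than this note shows. Statements on the series, on what has been measured and on what is new or still open speak of the compounds shown alone.

Of the compounds shown here, three on the shared core have been measured in a functional assay on HT-29 cells (Homo sapiens) for antiproliferative activity, read by MTT assay, with a stated time of 72 h; on this read-out lower numbers stand for stronger inhibition and higher numbers for weaker inhibition. They differ in the group on an aromatic nitrogen: propyl in compound 1 `CCCn1ccnc1-c1cc(OC)c(OC)c(OC)c1`, isopropyl in compound 2 `COc1cc(-c2nccn2C(C)C)cc(OC)c1OC` and 4-methylphenyl in compound 3 `COc1cc(-c2nccn2-c2ccc(C)cc2)cc(OC)c1OC`. In this assay compound 1 gives > 100000 nM, which is a limit. Compound 2 gives > 100000 nM, also a limit. Among the compounds with values here, compound 3 gives 1600 nM, the only actual number so far.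

The next step leads to compound 4 `COc1cc(-c2nccn2-c2ccc(Br)cc2)cc(OC)c1OC`. The change is bromo in place of methyl on an aromatic carbon, para to a large group, so that 4-methylphenyl becomes 4-bromophenyl.

Within the data shown here, two measured steps bear on it only indirectly, and both are large: an at least 62-fold lower number from compound 1 to compound 3 (1.79 log units; beyond the scatter) and an at least 62-fold lower number from compound 2 to compound 3 (1.79 log units; beyond the scatter). Both exchange an alkyl group for 4-methylphenyl, whereas compound 4 keeps the aromatic group and alters only its outer substituent. Among the measured compounds shown here, no measured step changes that substituent, so no step beyond the scatter is expected in this assay, and either direction remains possible. The expected change is a 1.1-fold lower number from compound 3 to compound 4 (0.03 log units; within the scatter). For compound 4 the estimated value is 1500 nM, with an expected range of 400 nM to 6000 nM.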

Compound 4, half-maximal inhibitory concentration: 7700 nM
Estimate against measurement, compound 4: 5.1-fold (0.71 log units) below, outside the stated range (above it).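

In this assay, the outer substituent on the aromatic group proves to matter: bromo in place of methyl on an aromatic carbon, para to a large group, gives a 4.8-fold higher number from compound 3 to compound 4 (0.68 log units; beyond the scatter), so this position responds to the exchange of a single heavy atom, with no hydrogen-bond donor or acceptor entering or leaving. The aromatic group on the nitrogen still separates clearly from the alkyl groups with bromo in place, with an at least 12-fold lower number from compound 2 to compound 4 (1.11 log units; beyond the scatter) and with an at least 12-fold lower number from compound 1 to compound 4 (1.11 log units; beyond the scatter), so 4-bromophenyl keeps a large step over propyl and isopropyl while standing on the weaker side of 4-methylphenyl. Both of these steps are bounds, not sizes, and how far the alkyl compounds really lie from compound 4 stays unread: the limit of > 100000 nM in this assay, at which 2 of the 4 values shown sit.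

The compounds shown hold only methyl and bromo at this position, so whether the higher number of compound 4 is particular to bromo or would follow from chloro, methoxy or an amine in the same place remains open. Also open, as far as these compounds go, is whether anything on the nitrogen short of a phenyl ring, such as a longer chain or a benzyl group, gives a readable number.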